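The compounds below may be only part of what the source reports. "The series", "measured", "known", "first", "only" and "open" are said of these compounds alone.

In a functional assay on SGC-7901 cells (Homo sapiens) for antiproliferative activity, read by sulforhodamine B assay, with a stated time of 72 h (on this read-out lower numbers stand for stronger inhibition and higher numbers for weaker inhibition), compound 3 `Cc1ccccc1NC(=S)N/N=C/c1ccc2ccccc2n1`, which carries 2-methylphenyl on an amide-type nitrogen, reads > 100000 nM, and this is a limit, not a number. Compound 1 `Cc1cccc(NC(=S)N/N=C/c2ccc3ccccc3n2)c1`, with 3-methylphenyl in that place, reads > 100000 nM, which is also a limit. Compound 2 `NC(=S)N/N=C/c1ccc2ccccc2n1`, with hydrogen there, gives a true number of 32700 nM. Compound 1 and compound 3 therefore share (the limit of > 100000 nM in this assay, at which 2 of the 3 values shown sit).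

Compound 4 `Fc1ccc(NC(=S)N/N=C/c2ccc3ccccc3n2)cc1` has 4-fluorophenyl in place of 2-methylphenyl on the amide-type nitrogen: 4-fluorophenyl in place of 2-methylphenyl on an amide-type nitrogen. The closest measured evidence is an at least 3.0-fold higher number from compound 2 to compound 3 (0.48 log units; beyond the scatter), and in the opposite sense an at least 3.0-fold lower number from compound 1 to compound 2 (0.48 log units; beyond the scatter). Both steps show that an aryl group here goes with weaker inhibition than hydrogen, while a step that the two limits leave unreadable from compound 1 to compound 3 gives no usable size. Within the data shown here, no measured compound carries fluorine, so the range must stay wide. Compound 4 keeps an aryl group, so little change is expected, perhaps a slight drop in the number, and the assay may again report only a limit. The expected step is an at least 1.2-fold lower number from compound 3 to compound 4 (0.09 log units; that floor lies within the scatter). For compound 4 the estimate is 80000 nM, with an expected range from 20000 nM to 200000 nM.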

Compound 4, half-maximal inhibitory concentration: 32300 nM
Compound 4: middle estimate off by 2.5-fold (0.39 log units), on the high side; the measured number falls inside the stated range.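

The aryl group on this amide-type nitrogen does not by itself go with weaker inhibition in this assay: 4-fluorophenyl in place of hydrogen gives a 1.0-fold lower number from compound 2 to compound 4 (0.01 log units; within the scatter). The choice of aryl group does matter, as 4-fluorophenyl in place of 2-methylphenyl gives an at least 3.0-fold lower number from compound 3 to compound 4 (0.49 log units; beyond the scatter), and in place of 3-methylphenyl it gives an at least 3.0-fold lower number from compound 1 to compound 4 (0.49 log units; beyond the scatter). Both of these steps give only a minimum size, because each starts from a limit rather than a true number: the limit of > 100000 nM in this assay, at which 2 of the 4 values shown sit.

Going by these compounds, it remains open whether the fluorine or the absence of the methyl group accounts for the difference, and how plain phenyl, 4-chlorophenyl or 4-methoxyphenyl would read on this nitrogen. Also open, on these data alone, is whether a simple alkyl chain such as ethyl or butyl there would read closer to hydrogen or to the methylphenyl groups.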